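This account rests on a few compounds, and the source may have more. Where it says the series, first, only, none or still open, it means among the compounds named here.

Compound 1 `CCNc1cc(Oc2c(OC)cc3cc(C#N)ccc3c2OC)nc(Nc2ccc(C#N)cc2)n1` was tested in an ADME assay on MT4 cells (Homo sapiens) for cytotoxicity, read by MTT assay, with a stated time of 5 days; on this read-out higher numbers stand for lower toxicity in this test and lower numbers for higher toxicity in this test. In this assay compound 1 gives > 125000 nM, which is a limit of the assay rather than a number. Two close relatives were measured alongside it. Compound 2 `COc1cc2cc(C#N)ccc2c(OC)c1Oc1cc(NC2CCC2)nc(Nc2ccc(C#N)cc2)n1` carries a cyclobutyl in place of the ethyl on a nitrogen on an aromatic ring, and compound 3 `COc1cc2cc(C#N)ccc2c(OC)c1Oc1cc(NCCC2=CCCCC2)nc(Nc2ccc(C#N)cc2)n1` carries a 2-(cyclohex-1-en-1-yl)ethyl at that same nitrogen. In this assay compound 2 gives > 125000 nM, again a limit. In this assay compound 3 gives > 125000 nM, also a limit. The steps a step that the two limits leave unreadable from compound 1 to compound 2, a step that the two limits leave unreadable from compound 1 to compound 3 and a step that the two limits leave unreadable from compound 2 to compound 3 are therefore all unreadable, because of the limit of > 125000 nM in this assay, at which 3 of the 3 values shown sit.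

Compound 4 `COc1cc2cc(C#N)ccc2c(OC)c1Oc1cc(NC2CCOCC2)nc(Nc2ccc(C#N)cc2)n1` differs from compound 1 as follows: oxan-4-yl in place of ethyl on a nitrogen on an aromatic ring. The three measured steps all involve changes at this same nitrogen and none of them produced a readable number, so no direction or size can be drawn from them. Compound 4 is expected to behave like its relatives, with an estimated step of a number no higher from compound 1 to compound 4 (the limit leaves the size open). For compound 4 the estimated value is 125000 nM, within a range from 60000 nM to 250000 nM, and most likely the assay will again report only a limit.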

Compound 4, half-maximal cytotoxic concentration: > 125000 nM
Compound 4: only a limit was reported (the forecaster's own chance of this, stated with the estimate: 85%); the middle value lies on the limit itself.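

The steps between compound 4 and compound 1, compound 2 and compound 3 cannot be read, because all four compounds stop at the same assay limit: the limit of > 125000 nM in this assay, at which 4 of the 4 values shown sit. As far as these compounds go, whether any of these groups on the nitrogen changes the result in this assay, and by how much, stays open.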